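Ring-opened amine variant of a GPR88 agonist series

A few compounds are considered here, and "the series" means these few. Any claim that something is new, unique, unknown or untested is made for them only; others in the source may bear on it.

Going by the values given here, compound 2 `O=C([C@@H]1C[C@H]1c1ccccc1)N(CC1CCCNC1)c1ccc(-c2ccccc2)cc1` is one of two compounds measured in a functional assay for agonist activity at G protein-coupled receptor 88 (Homo sapiens), read by HTRF and cAMP accumulation (a lower number here means that less compound is needed, a higher number that more compound is needed for the effect), and in this assay compound 2 gives 10 nM. Among the compounds with values here, compound 1 `CN[C@@H](CC(C)C)CN(C(=O)[C@@H]1C[C@H]1c1ccccc1)c1ccc(-c2ccccc2)cc1` carries a different amine on the chain carbon bound to the amide-type nitrogen, and in this assay compound 1 gives 2 nM; the only measured step, a 5.0-fold higher number from compound 1 to compound 2 (0.70 log units; beyond the scatter), leaves compound 2 with the higher of the two numbers. Compound 3 `O=C([C@@H]1C[C@H]1c1ccccc1)N(CCNCC1CCCCC1)c1ccc(-c2ccccc2)cc1` differs from compound 2 by ((cyclohexylmethyl)amino)methyl in place of piperidin-3-yl on a saturated chain carbon bound to an amide-type nitrogen. Within the data shown here, that step bears on the one measured step only loosely: compound 1, like compound 3, carries an open-chain secondary amine rather than a ring, and compound 1 gave the lower number. He therefore expects compound 3 to move toward compound 1, with the step of a 1.7-fold lower number from compound 2 to compound 3 (0.22 log units; within the scatter) estimated as small and downward, though it may well stay within the scatter. His estimate for compound 3 in this assay is 6 nM, within the range 2 nM to 30 nM.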

Compound 3, half-maximal effective concentration: 6.6 nM
Compound 3: the middle estimate sits 1.1-fold (0.04 log units) below what was measured, within the range that was stated.
By their numbers in this assay, from the lowest: compound 1; then compounds 3 and 2 (each within the scatter of the next).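

In this assay, the position on the saturated chain carbon bound to the amide-type nitrogen accepts ((cyclohexylmethyl)amino)methyl in place of piperidin-3-yl with no change that stands out from the scatter, at a 1.5-fold lower number from compound 2 to compound 3 (0.18 log units; within the scatter). An open-chain secondary amine alone therefore does not bring the number to that of compound 1, since 3-methyl-1-(methylamino)butyl still holds its lead, with ((cyclohexylmethyl)amino)methyl in its place giving a 3.3-fold higher number from compound 1 to compound 3 (0.52 log units; beyond the scatter). No supporting measurement is available to explain either step.

As far as these compounds go, whether the carbon-only ring in compound 3 matters remains open, and a phenyl ring in its place or an open isobutyl group would speak to that. Equally open, from the compounds shown here alone, is how a primary amine would fare in place of the secondary amine at this position.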